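The compounds below may be only part of what the source reports. "The series", "measured", "known", "first", "only" and "open" are said of these compounds alone.

Compound 1 `CCc1cn(/C=C\COC(c2ccccc2)(c2ccccc2)c2ccccc2)c(=O)[nH]c1=O`: 20000 nM
Compound 2 `Cc1cn(C/C=C\COC(=O)C(C)(C)C)c(=O)[nH]c1=O`: 40000 nM

Both were tested in an assay on isolated protein for inhibition of thymidine kinase, cytosolic (Homo sapiens); on this read-out higher numbers stand for weaker inhibition and lower numbers for stronger inhibition. Compound 2 gives 40000 nM, the higher of the two numbers, and compound 1 at 20000 nM sits within the scatter of it, so neither counts as the weaker one. Compound 3 `Cc1cn(C/C=C\COCc2ccccc2)c(=O)[nH]c1=O` differs from compound 2 by benzyl in place of (tert-butyl)carbonyl on an oxygen on a saturated carbon. Within the data shown here, no measured pair shows this change alone, so no step beyond the scatter is expected in either direction. Compound 3 is therefore estimated at 30000 nM in this assay, between 8000 nM and 100000 nM, an expected step of a 1.3-fold lower number from compound 2 to compound 3 (0.12 log units; within the scatter).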

Compound 3, half-maximal inhibitory concentration: 22000 nM
Compound 3: the middle estimate sits 1.4-fold (0.13 log units) above what was measured, within the range that was stated.
By their numbers in this assay, from the lowest: compounds 1, 3 and 2 (each within the scatter of the next).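

Moving from the ester to the ether in this assay, with benzyl in place of (tert-butyl)carbonyl on an oxygen on a saturated carbon, gives a 1.8-fold lower number from compound 2 to compound 3 (0.26 log units; within the scatter) and so no readable change. This position therefore takes a six-membered aromatic ring of carbon only, and the loss of the hydrogen-bond acceptor of the group that leaves, without a step beyond the scatter. No measured evidence offers an explanation for this result. Still open, as far as these compounds go, is whether an amine or a carboxylic acid on this oxygen-bearing chain would shift the number beyond the scatter.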